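The compounds below may be only part of what the source reports. "The series", "measured", "known", "first", "only" and "open" are said of these compounds alone.

Measured so far:
compound 1 `O=C(c1ccc(F)c(O)c1)c1ccc2cc(O)ccc2n1`: 119 nM
compound 2 `CN(c1ccc(F)c(O)c1)c1cccc(-c2cccc(O)c2F)n1`: 42 nM

In an assay for binding affinity to 17-beta-hydroxysteroid dehydrogenase 14 (Homo sapiens), read by fluorescence, with a stated time of 15 min, in the presence of a further agent that is not named here (a lower number here means a stronger inhibitor, a higher number a weaker inhibitor), compound 1 gives 119 nM. Compound 2, which rests on a different core, gives 42 nM in this assay. Compound 1 therefore carries the higher of the two numbers, and its gap to compound 2 lies beyond the scatter. Among the measured compounds shown here, with only two compounds measured, and no pair differing in one place, no step has yet been seen.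

Compound 3 `O=C(c1ccc(F)c(O)c1)c1ccc2ccccc2n1` is not yet measured. Against compound 1 the change is hydrogen in place of hydroxy on an aromatic carbon, in words hydrogen in place of hydroxy on an aromatic carbon; the rest of compound 1 is kept.

For the measured compounds named here, since no measured pair shows this change, the expectation rests on the change itself. Removing a group that counts as one hydrogen-bond donor and one acceptor is expected to cost some affinity, so the step from compound 1 to compound 3 in this assay is expected to be upward, a 2.9-fold higher number from compound 1 to compound 3 (0.47 log units; beyond the scatter), of moderate size rather than drastic. Compound 3 is accordingly expected near 350 nM, within 120 nM to 1200 nM.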

Compound 3, inhibition constant: 12 nM
The estimate for compound 3 lay 29-fold (1.46 log units) above the measured number; the whole stated range lies above it.
By their numbers in this assay, from the lowest: compound 3; then compound 2; then compound 1.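

In this assay, hydrogen in place of hydroxy on an aromatic carbon of the fused two-ring system gives a 9.9-fold lower number from compound 1 to compound 3 (1.00 log units; beyond the scatter), so this hydroxy, meta to a fused ring and para to a fused ring, is not required for a low number in this pair. Among the compounds shown here, its removal takes away one hydrogen-bond donor and one hydrogen-bond acceptor, yet inhibition becomes stronger, a direction that the earlier compounds, with no pair differing in one place, could not reveal. Nothing at hand bears on why the step runs in this direction.

The shown compounds leave open whether the gain comes from the mere absence of the hydroxy or whether another group on the same carbon, such as methoxy, fluorine or an amine, would keep or extend it. From the compounds shown here alone, the contribution of the hydroxy and fluorine retained on the other ring of compound 3 also remains open, and this single pair gives no basis for carrying the result over to another core.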